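Lengthening the amide chain in a methoxyphenylpropyl series

The compounds below may be only part of what the source reports. "The series", "measured", "known", "first", "only" and "open" are said of these compounds alone.

Measured so far in an assay for binding affinity to melatonin receptor (Gallus gallus); a higher number here means a weaker inhibitor, a lower number a stronger inhibitor:
compound 1, `COc1ccccc1CCCNC(C)=O`, gives 1430 nM;
compound 2, `CCC(=O)NCCCc1ccccc1OC`, gives 374 nM;
compound 3, `CCCC(=O)NCCCc1ccccc1OC`, gives 442 nM.

Compound 3 has the second highest of the three numbers, nearest compound 2 and furthest from compound 1. Compound 4, `CCCCC(=O)NCCCc1ccccc1OC`, differs from compound 3 by methyl in place of hydrogen on a saturated chain carbon, three bonds along the chain from a carbonyl carbon. Going by the values given here, two measured steps bear on this change: a 3.8-fold lower number from compound 1 to compound 2 (0.58 log units; beyond the scatter) and a 1.2-fold higher number from compound 2 to compound 3 (0.07 log units; within the scatter). The first lengthening of the chain brought a modest gain, the second none beyond the scatter, so a further lengthening is expected to move this assay by no more than the scatter, in no clear direction. Compound 4 is therefore estimated at 420 nM, between 200 nM and 900 nM, the expected step being a 1.1-fold lower number from compound 3 to compound 4 (0.02 log units; within the scatter).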

Compound 4, inhibition constant: > 100000 nM
Compound 4 gave a limit, no number; the forecaster's own chance of this, stated with the estimate: 3%; middle value at least 230-fold (2.37 log units) away from the limit.
By their numbers in this assay, from the lowest: compounds 2 and 3 (each within the scatter of the next); then compound 1. At a limit, above all of these: compound 4.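

In this assay compound 4 gives only a limit, > 100000 nM. At this place, three bonds along the chain from a carbonyl carbon, methyl in place of hydrogen is a large loss, an at least 220-fold higher number from compound 3 to compound 4 (2.35 log units; beyond the scatter), and the gap also stands against the shorter chains, with an at least 260-fold higher number from compound 2 to compound 4 (2.42 log units; beyond the scatter) and an at least 69-fold higher number from compound 1 to compound 4 (1.84 log units; beyond the scatter). The earlier compounds showed only a gain or no change on lengthening, whereas the same change now acts in opposite directions on different cores: the same change on two cores in this assay, a 3.8-fold lower number (0.58 log units; beyond the scatter) from compound 1 to compound 2 and an at least 220-fold higher number (2.35 log units; beyond the scatter) from compound 3 to compound 4, at least 860-fold (2.93 log units) apart, beyond the scatter of two such steps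

The compounds shown leave open whether a longer chain, or a chain ending in a hydroxyl or an amine, would behave as compound 4 does.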